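Amino in Place of Hydroxy: What Compound 3 Should Give

The compounds below may be only part of what the source reports. "The series", "measured", "known", "first", "only" and "open" are said of these compounds alone.

Compound 1, `C=CCSS[C@H]1C[C@H](n2cc(C)c(=O)[nH]c2=O)O[C@@H]1CO`, in a physicochemical assay for pharmacokinetics, at pH 7.2; on this read-out lower numbers stand for a shorter-lived compound and higher numbers for a longer-lived compound: compound 1 gives < 0.0834 h, a limit of the assay.
Compound 2, `Cc1cn([C@H]2C[C@H](SSCCO)[C@@H](CO)O2)c(=O)[nH]c1=O`, in this assay: compound 2 gives < 0.0834 h, again a limit of the assay.

Compound 2 therefore stands at the lower edge of what this assay can report; its value is a limit and not a number, and both values shown sit there, as the limit of < 0.0834 h in this assay, at which 2 of the 2 values shown sit, records. The step that the two limits leave unreadable from compound 1 to compound 2 accordingly cannot be sized from the two limits.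

Compound 3, `Cc1cn([C@H]2C[C@H](SSCCN)[C@@H](CO)O2)c(=O)[nH]c1=O`, differs from compound 2 by amino in place of hydroxy on a saturated chain carbon, two bonds along the chain from a sulfur. For the measured compounds named here, the only measured step that touches the same chain, from compound 1 to compound 2, is itself unreadable, so the data give no measured size for a change of this kind. With both measured compounds at the limit, the expectation is that compound 3 again sits at or close to it, and the step that the limit leaves unreadable from compound 2 to compound 3 is estimated as no step beyond the scatter. Compound 3 is expected to give about 0.05 h in this assay, within 0.02 h to 0.15 h.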

Compound 3, half-life: < 0.0834 h
Compound 3: a limit, no number; the forecaster's own chance of this, stated with the estimate: 75%; the middle value is on the limit's open side.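

In this assay compound 3 gives < 0.0834 h, a limit of the assay and not a number. For the compounds shown here, no step among compound 1, compound 2 and compound 3 can be read, since all three sit at the same edge: the limit of < 0.0834 h in this assay, at which 3 of the 3 values shown sit. The compounds shown leave open what the half-life of each one is, and whether amino in place of hydroxy changes it at all.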